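The compounds below may be only part of what the source reports. "The series", "measured", "known", "first", "only" and "open" are said of these compounds alone.

Compound 1 `Cc1cccc(-n2nncc2CN2C(=O)C3(C(C#N)=C(N)Oc4c3c3nc5ccccc5nc3c3ccccc43)c3ccccc32)c1` is the reference point of the set; in a functional assay on A549 cells (Homo sapiens) for antiproliferative activity, read by MTT assay, with a stated time of 48 h (on this read-out higher numbers stand for weaker inhibition and lower numbers for stronger inhibition), compound 1 gives 39600 nM. Compound 2 `N#CC1=C(N)Oc2c(c3nc4ccccc4nc3c3ccccc23)C12C(=O)N(Cc1cnnn1-c1ccccc1Cl)c1ccccc12` in this assay gives 42600 nM. Compound 3 `N#CC1=C(N)Oc2c(c3nc4ccccc4nc3c3ccccc23)C12C(=O)N(Cc1cnnn1-c1cccc(Br)c1)c1ccccc12` in this assay returns only a limit, > 50000 nM, and not a number. Compound 3 thus stands at the limit of > 50000 nM in this assay, at which 1 of the 3 values shown sits, with no resolved value of its own. Across the three, a 1.1-fold higher number from compound 1 to compound 2 (0.03 log units; within the scatter), an at least 1.2-fold higher number from compound 1 to compound 3 (0.10 log units; that floor lies within the scatter) and an at least 1.1-fold higher number from compound 2 to compound 3 (0.06 log units; that floor lies within the scatter); none of these separates the compounds beyond the scatter. Compound 4 `CCOc1ccc(-n2nncc2CN2C(=O)C3(C(C#N)=C(N)Oc4c3c3nc5ccccc5nc3c3ccccc43)c3ccccc32)cc1` carries the change (4-ethoxyphenyl in place of 3-bromophenyl on an aromatic nitrogen), on an aromatic nitrogen of the five-membered aromatic ring with three nitrogen. The three measured steps are the only ones that bear on it: each is an exchange of the phenyl on that nitrogen, and each is small. The expected step in this assay is therefore an at least 1.1-fold lower number from compound 3 to compound 4 (0.04 log units; that floor lies within the scatter), none beyond the scatter, with a real chance that compound 4 again returns only a limit. Compound 4 is estimated at 45000 nM, expected to fall between 25000 nM and 90000 nM.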

Compound 4, half-maximal inhibitory concentration: 25200 nM
The estimate for compound 4 lay 1.8-fold (0.25 log units) above the measured number; the measured number falls inside the stated range.
By their numbers in this assay, from the lowest: compounds 4, 1 and 2 (each within the scatter of the next). At a limit, above all of these: compound 3.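

In this assay, 4-ethoxyphenyl, which counts a hydrogen-bond acceptor where 3-bromophenyl has none, gives a resolved number on this aromatic nitrogen, whereas compound 3 reads only as a limit: the limit of > 50000 nM in this assay, at which 1 of the 4 values shown sits. The steps to compound 4 are an at least 1.9-fold lower number from compound 3 to compound 4 (0.29 log units; that floor lies within the scatter) and a 1.7-fold lower number from compound 2 to compound 4 (0.23 log units; within the scatter) and a 1.6-fold lower number from compound 1 to compound 4 (0.20 log units; within the scatter), so none separates compound 4 from the others. This aromatic nitrogen therefore accepts 4-ethoxyphenyl, with more heavy atoms than 3-bromophenyl, without a shift beyond the scatter.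

From the compounds shown here alone, whether any group at this position can move the number beyond the scatter remains open. A phenyl carrying an amine or a carboxylic acid, or a simple alkyl chain in place of the phenyl, would extend the comparison beyond these four aryl groups.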